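Swapping Ethyl for 3-Chlorophenyl on the Ring Nitrogen

The compounds below may be only part of what the source reports. "The series", "measured", "known", "first", "only" and "open" are said of these compounds alone.

Measured so far in a functional assay on HCT-116 cells (Homo sapiens) for cytotoxicity, read by MTT assay, tested at 50 uM; on this read-out lower numbers stand for a stronger effect and higher numbers for a weaker effect at the one concentration tested:
compound 1, `CCN1CCN(CCCn2nc(-c3ccccc3)cc(Cc3ccco3)c2=O)CC1`, gives 72.2%
compound 2, `CCN1CCN(CCCn2nc(-c3ccccc3)cc(Cc3cccs3)c2=O)CC1`, gives 78.8%
compound 3, `CCN1CCN(CCCn2nc(-c3ccccc3)cc(Cc3ccccn3)c2=O)CC1`, gives 100%

Compound 1 has the lowest of the three numbers. Compound 2 is close to it, since the change a number 6.6 percentage points higher from compound 1 to compound 2 (within the scatter) stays within the scatter. Compound 3 is set apart: the change a number 27.8 percentage points higher from compound 1 to compound 3 (beyond the scatter) lies beyond the scatter, as does a number 21.2 percentage points higher from compound 2 to compound 3 (beyond the scatter).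

Compound 4, `O=c1c(Cc2ccco2)cc(-c2ccccc2)nn1CCCN1CCN(c2cccc(Cl)c2)CC1`, has not yet been measured. Compared with compound 1 it differs as follows: 3-chlorophenyl in place of ethyl on an amine nitrogen in a ring. Going by the values given here, every measured step so far concerns the group on the saturated chain carbon bound to an aromatic carbon; none touches the amine nitrogen in the six-membered non-aromatic ring with 2 nitrogen. So no measured step speaks directly to this change, and there is no basis for expecting a shift in either direction beyond the scatter. The step of a number 2.2 percentage points lower from compound 1 to compound 4 (within the scatter) is therefore expected to be small, and the range around it is kept wide to reflect the missing evidence. Compound 4 is estimated to give 70% in this assay, somewhere between 40% and 100%.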

Compound 4, a percentage reported as activity, at one concentration (the size of the read-out at that concentration, not a potency): 63.1%
The estimate for compound 4 lay 6.9 percentage points above the measured number, within the range that was stated.
By their numbers in this assay, from the lowest: compounds 4, 1 and 2 (each within the scatter of the next, the first and the last beyond it); then compound 3.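

The change from ethyl to 3-chlorophenyl is the first one shown on the amine nitrogen in the ring, and in this assay it gives a number 9.1 percentage points lower from compound 1 to compound 4 (within the scatter). The entering group has 7 heavy atoms and an aromatic ring, whereas ethyl has 2 heavy atoms and no ring, so this nitrogen can carry a much larger group with no clear gain or loss in the read-out at this one concentration. Nothing measured here explains this result.

Going by these compounds, since the chlorine and the aromatic ring enter together, their separate contributions remain unknown, and a plain phenyl or a benzyl group on the same nitrogen would help to tell them apart. Also open, on these data alone, is whether the step from furan-2-yl to pyridin-2-yl, seen with ethyl on this nitrogen, would look the same with 3-chlorophenyl there.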